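Removal of the aryl methoxy group in a thiazolyl ketone series

A few compounds are considered here, and "the series" means these few. Any claim that something is new, unique, unknown or untested is made for them only; others in the source may bear on it.

Measured so far, in a functional assay on U-87MG ATCC cells for antiproliferative activity against U-87 MG (Homo sapiens), read by MTT assay, with a stated time of 48 h, tested at 10 uM; on this read-out lower numbers stand for a stronger effect and higher numbers for a weaker effect at the one concentration tested:
compound 1 `COc1ccc(-c2nc(C)c(C(=O)CSc3nc(-c4ccc(OC)c(OC)c4)c(C#N)c(=O)[nH]3)s2)cc1`, where compound 1 gives 57.6%
compound 2 `COc1ccc(-c2nc(SCC(=O)c3sc(-c4ccccc4)nc3C)[nH]c(=O)c2C#N)cc1OC`, where compound 2 gives 69.8%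
compound 3 `COc1ccc(-c2nc(SCC(=O)c3sc(-c4ccc(Cl)cc4)nc3C)nc(N)c2C#N)cc1`, where compound 3 gives 64.5%

Compound 2 differs from compound 1 by one change, (hydrogen in place of methoxy on an aromatic carbon), and this gave the step of a number 12.2 percentage points higher from compound 1 to compound 2 (beyond the scatter). Compound 3 carries a different core; the difference between the core of compound 1 and the core of compound 3 is not broken down here. Compound 3 lies within the scatter of both compound 1 and compound 2.

Compound 4 `Cc1nc(-c2ccc(Cl)cc2)sc1C(=O)CSc1nc(N)c(C#N)c(-c2ccccc2)n1` is not yet measured. It differs from compound 3 by the same change, (hydrogen in place of methoxy on an aromatic carbon), at the same place as before. Resting on the single earlier instance, the step from compound 3 to compound 4 in this assay is expected to be a number 9.5 percentage points higher from compound 3 to compound 4 (within the scatter). Compound 4 is thus estimated at 74%, most likely between 60% and 88%.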

Compound 4, a percentage reported as activity, at one concentration (the size of the read-out at that concentration, not a potency): 67.9%
Beside the measured number, compound 4's estimate is 6.1 percentage points above it, and the stated range covers the measured number.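

In this assay, hydrogen in place of methoxy on the aromatic carbon gives a number 3.4 percentage points higher from compound 3 to compound 4 (within the scatter) on the core of compound 3. Set beside the earlier instance, the size of the step does not separate the two cores: the same change on two cores in this assay, a number 12.2 percentage points higher (beyond the scatter) from compound 1 to compound 2 and a number 3.4 percentage points higher (within the scatter) from compound 3 to compound 4, 8.8 percentage points apart, within the scatter of two such steps

So one shared step size across these cores remains compatible with the data, but two pairs do not establish it, and the step on the core of compound 3 cannot by itself be told from scatter. Hydrogen is the only replacement for methoxy shown here. On these data alone, whether a hydroxyl, an ethoxy or a dimethylamino group at that place would behave differently remains open, as does the same change on any further core.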